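Moving the halogen around a phenyl ring on the shared core

This account rests on a few compounds, and the source may have more. Where it says the series, first, only, none or still open, it means among the compounds named here.

Three compounds share one core and differ only in the aromatic group on a saturated ring carbon. Compound 1 `CCOC(=O)C12C(=O)OCC=C1COC2c1ccccc1F` carries a 2-fluorophenyl group there. In a functional assay on A549 cells (Homo sapiens) for cytotoxicity, read by MTT assay (on this read-out lower numbers stand for stronger inhibition and higher numbers for weaker inhibition), compound 1 gives only a limit, > 1000000 nM. Going by the values given here, compound 2 `CCOC(=O)C12C(=O)OCC=C1COC2c1cccc(Cl)c1` carries a 3-chlorophenyl group instead, and in this assay compound 2 gives 28400 nM, the only real number recorded so far. The step of an at least 35-fold lower number from compound 1 to compound 2 (1.54 log units; beyond the scatter) shows that the change of aromatic group matters a great deal, though the size rests on (the limit of > 1000000 nM in this assay, at which 1 of the 2 values shown sits).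

Compound 3 `CCOC(=O)C12C(=O)OCC=C1COC2c1ccc(Br)cc1` continues along the same line: 4-bromophenyl in place of 3-chlorophenyl on a saturated ring carbon. Among the compounds with values here, no measured step covers the move from a 3-chlorophenyl to a 4-bromophenyl group, and the single step from compound 1 to compound 2 gives no clear direction for it. The expectation is therefore a step of a 1.1-fold higher number from compound 2 to compound 3 (0.02 log units; within the scatter) in this assay that stays within the scatter, with wide uncertainty. Compound 3 is estimated at 30000 nM, in a range from 7000 nM to 150000 nM.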

Compound 3, half-maximal inhibitory concentration: > 1000000 nM
Compound 3: a limit, no number; the forecaster's own chance of this, stated with the estimate: 25%; middle value at least 33-fold (1.52 log units) from the limit.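

The step of an at least 35-fold higher number from compound 2 to compound 3 (1.54 log units; beyond the scatter) shows that replacing 3-chlorophenyl with 4-bromophenyl on this saturated ring carbon is far from a quiet exchange, even though both groups have the same count of heavy atoms and the same kind of aromatic ring. Of the three compounds, only compound 2 gives a real number in this assay, so a measurable result here goes with the 3-chlorophenyl group alone and not with halogen-bearing phenyl groups in general, a broader pattern that compound 1 and compound 3 both go against. Compound 3, like compound 1, gives only a limit, so the step between those two cannot be read, and the size of the new step also rests on a limit: the limit of > 1000000 nM in this assay, at which 2 of the 3 values shown sit.

Compound 3 differs from compound 2 in both the halogen and its place on the phenyl ring, so the compounds shown cannot separate these two changes; a 3-bromophenyl or a 4-chlorophenyl group would do that. They also leave open what happens at this position with an unsubstituted phenyl ring, or with a phenyl ring carrying an amine or a carboxylic acid.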